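Aryl amine variation on the shared core: toward compound 4

The compounds below may be only part of what the source reports. "The series", "measured", "known", "first", "only" and "open" are said of these compounds alone.

Measured so far:
compound 1, `C=C1[C@@H](OC(C)=O)C[C@@H]2[C@](C)(CO[Si](C)(C)C(C)(C)C)[C@H](OC(C)=O)CC[C@@]2(C)[C@@H]1C[C@@H](Nc1ccccc1F)C1=CCOC1=O`, 2930 nM
compound 2, `C=C1[C@@H](OC(C)=O)C[C@@H]2[C@](C)(COC=O)[C@H](OC(C)=O)CC[C@@]2(C)[C@@H]1C[C@@H](Nc1ccc(OC)c(OC)c1)C1=CCOC1=O`, > 50000 nM
compound 3, `C=C1[C@@H](OC(C)=O)C[C@@H]2[C@](C)(CO[Si](C)(C)C(C)(C)C)[C@H](OC(C)=O)CC[C@@]2(C)[C@@H]1C[C@@H](Nc1cccc2ccccc12)C1=CCOC1=O`, 5770 nM

In a functional assay on MCF7 cells (Homo sapiens) for cytotoxicity, read by sulforhodamine B assay (on this read-out higher numbers stand for weaker inhibition and lower numbers for stronger inhibition), compound 1 gives 2930 nM, and compound 3 gives 5770 nM. For the measured compounds named here, the one measured step, a 2.0-fold higher number from compound 1 to compound 3 (0.29 log units; within the scatter), is within the scatter, so the two cannot be ordered. Going by the values given here, compound 2 stands apart: in this assay compound 2 gives only a limit, > 50000 nM, not a number, and it is the one value sitting at the limit of > 50000 nM in this assay, at which 1 of the 3 values shown sits.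

Compound 4, `C=C1[C@@H](OC(C)=O)C[C@@H]2[C@](C)(COC=O)[C@H](OC(C)=O)CC[C@@]2(C)[C@@H]1C[C@@H](Nc1cccc(F)c1)C1=CCOC1=O`, carries the change (3-fluorophenyl in place of 3,4-dimethoxyphenyl on an amine nitrogen). Among the compounds with values here, no measured step covers this change on the core of compound 2; the step from compound 1 to compound 3 concerns a different pair of groups on a different core variant and is within the scatter, so it gives no direction. The only aryl fluorine among the measured compounds, compound 1, gives a number in this assay, whereas compound 2 gives only a limit. For compound 4 a step of an at least 2.5-fold lower number from compound 2 to compound 4 (0.39 log units; beyond the scatter) from the limit is expected, with wide uncertainty. In this assay compound 4 is estimated at 20000 nM, between 3000 nM and 50000 nM.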

Compound 4, half-maximal inhibitory concentration: 14100 nM
Compound 4: middle estimate off by 1.4-fold (0.15 log units), on the high side; the range from low to high includes it.
By their numbers in this assay, from the lowest: compounds 1 and 3 (each within the scatter of the next); then compound 4. At a limit, above all of these: compound 2.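

In this assay, 3-fluorophenyl in place of 3,4-dimethoxyphenyl on the amine nitrogen, on the core of compound 2, gives a step beyond the scatter (an at least 3.5-fold lower number from compound 2 to compound 4 (0.54 log units; beyond the scatter)), so on this core the aryl group does change the read-out. The other step shown (a 2.0-fold higher number from compound 1 to compound 3 (0.29 log units; within the scatter)) belongs to a different core variant and gave no such reading. The size of the new step is only a minimum, since its starting value for compound 2 is a limit: the limit of > 50000 nM in this assay, at which 1 of the 4 values shown sits.

As far as these compounds go, whether the shift follows from losing the two methoxy groups or from gaining the fluorine stays open, and an unsubstituted phenyl on the same nitrogen would separate the two. Also open, from the compounds shown here alone, is how 3-fluorophenyl behaves on the core of compound 1.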